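The source may report more compounds than this note shows. Statements on the series, on what has been measured and on what is new or still open speak of the compounds shown alone.

Measured in an ADME assay on cells (Hepatocyte, Mus musculus) for metabolic stability, with a stated time of 30 min; a lower number here means that less of the compound is left, a higher number that more of the compound is left:

- Compound 1 `O=c1cc(N2CCN(CC3CCC(NS(=O)(=O)c4ccccc4)CC3)CC2)sc2c([N+](=O)[O-])cc(C(F)(F)F)cc12`: 95.3%
- Compound 2 `O=C(OC1CCC(CN2CCN(c3cc(=O)c4cc(C(F)(F)F)cc([N+](=O)[O-])c4s3)CC2)CC1)c1ccncc1`: 1.4%
- Compound 3 `O=C(OC1CCC(CN2CCN(c3cc(=O)c4cc(C(F)(F)F)cc([N+](=O)[O-])c4s3)CC2)CC1)c1ccc(C(F)(F)F)cc1`: 28.8%

Among these, compound 3, at 28.8%, holds the middle place, lying beyond the scatter from both of the others. The next compound, compound 4 `O=C(OC1CCC(CN2CCN(c3cc(=O)c4cc(C(F)(F)F)cc([N+](=O)[O-])c4s3)CC2)CC1)C1CCCCC1`, changes only the group on the carbonyl carbon: cyclohexyl in place of 4-(trifluoromethyl)phenyl on a carbonyl carbon. Cyclohexyl takes the place of 4-(trifluoromethyl)phenyl, and it has not yet been measured at this position.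

Going by the values given here, the closest evidence is the only measured change at this carbonyl carbon, a number 27.4 percentage points higher from compound 2 to compound 3 (beyond the scatter), so swapping this group has already moved this assay by a modest amount. The other step, a number 93.9 percentage points lower from compound 1 to compound 2 (beyond the scatter), is large, but it replaces the whole (phenylsulfonyl)amino group and so bears on compound 4 only indirectly. It does show that compound 2 and compound 3, which share the carbonyl-oxy link with compound 4, both lie far below compound 1. A modest fall is therefore expected rather than a return towards compound 1, although a rise cannot be ruled out.

The expected step is a number 13.8 percentage points lower from compound 3 to compound 4 (beyond the scatter). For compound 4 the estimated value is 15%, with an expected range from 2% to 45%.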

Compound 4, percent of the compound remaining: 1.2%
The estimate for compound 4 lay 13.8 percentage points above the measured number; the whole stated range lies above it.
By their numbers in this assay, from the lowest: compounds 4 and 2 (each within the scatter of the next); then compound 3; then compound 1.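

In this assay, three groups on the carbonyl carbon can now be compared, and only 4-(trifluoromethyl)phenyl stands apart: changing it to cyclohexyl gives a number 27.6 percentage points lower from compound 3 to compound 4 (beyond the scatter), whereas cyclohexyl in place of pyridin-4-yl gives a number 0.2 percentage points lower from compound 2 to compound 4 (within the scatter), so the split does not follow aromatic against saturated rings, with pyridin-4-yl going against such a reading. The large gap to the sulfonamide compound also holds with a saturated ring on the carbonyl carbon, as (cyclohexylcarbonyl)oxy in place of (phenylsulfonyl)amino gives a number 94.1 percentage points lower from compound 1 to compound 4 (beyond the scatter). No measurement given here accounts for these differences.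

On these data alone, it remains open whether the higher number of compound 3 belongs to the trifluoromethyl group or to the phenyl ring that carries it, a question that a plain phenyl or a 4-chlorophenyl on this carbonyl carbon would address. It is also open whether an amide link in place of the carbonyl-oxy link, carrying cyclohexyl or pyridin-4-yl, would give numbers nearer that of compound 1 or stay with those of the compounds shown here.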